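This account rests on a few compounds, and the source may have more. Where it says the series, first, only, none or still open, it means among the compounds named here.

Compound 1 `C[C@@H](O[C@@H]1[C@@H](c2ccccc2)CN(C(=O)OC(C)(C)C)[C@H]1CO)c1cc(C(F)(F)F)cc(C(F)(F)F)c1` sits at the weak end of the three numbers available: in an assay on CHO cells for displacement of a labelled ligand from Substance-P receptor (Homo sapiens) (on this read-out higher numbers stand for weaker inhibition and lower numbers for stronger inhibition), compound 1 gives 3.6 nM. The nearest neighbour is compound 3 `C[C@@H](O[C@@H]1[C@@H](c2ccccc2)CN2C(=O)OC[C@H]12)c1cc(C(F)(F)F)cc(C(F)(F)F)c1`, which in this assay gives 1.5 nM, a gap that lies beyond the scatter. Furthest off is compound 2 `C[C@@H](O[C@H]1CN2C(=O)NC[C@H]2[C@@H]1c1ccc(F)cc1)c1cc(C(F)(F)F)cc(C(F)(F)F)c1`, which in this assay gives 0.06 nM, far beyond the scatter from compound 1. None of these pairs is a single-point step, so only the bare values are compared here.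

Compound 4 `C[C@@H](O[C@H]1[C@H](c2ccccc2)CN(C(=O)OC(C)(C)C)[C@H]1CO)c1cc(C(F)(F)F)cc(C(F)(F)F)c1` is the diastereomer of compound 1: the two compounds have the same atoms and bonds and differ only in configuration as drawn: 2 of 4 stereo elements differ; a stereocentre at a saturated ring carbon is drawn R in compound 1 and S in compound 4; a stereocentre at a saturated ring carbon is drawn S in compound 1 and R in compound 4. Among the compounds with values here, no measured pair reports what such an inversion does, so the direction rests on the general observation that the two ring configurations shared by compounds 1, 2 and 3 carry the strong binding seen so far. For compound 4 a step beyond the scatter towards weaker inhibition is expected, a 14-fold higher number from compound 1 to compound 4 (1.14 log units; beyond the scatter), and the estimate in this assay for compound 4 is 50 nM, with a range from 8 nM to 400 nM.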

Compound 4, half-maximal inhibitory concentration: 7.8 nM
Compound 4: the middle estimate sits 6.4-fold (0.81 log units) above what was measured; the measured number lies below the stated range.
By their numbers in this assay, from the lowest: compound 2; then compound 3; then compound 1; then compound 4.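

In this assay the series now has its first single-change step, a 2.2-fold higher number from compound 1 to compound 4 (0.34 log units; beyond the scatter), and this step can be assigned to configuration alone because nothing else separates the pair: the fact that compounds 1 and 4 differ only in the configuration as drawn. The step is modest, so the configuration drawn in compound 1 at these two saturated ring carbons is favoured only slightly. It is not a condition for binding in this pair, as compound 4 still gives 7.8 nM.

Going by these compounds, both stereocentres change together, so what each contributes on its own stays open. Also open, on these data alone, is whether the same small preference would hold in the configurations of compounds 2 and 3, or in a compound carrying an amine or a carboxylic acid on the core of compound 1.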